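This account rests on a few compounds, and the source may have more. Where it says the series, first, only, none or still open, it means among the compounds named here.

Of the compounds shown here, three have been measured in an ADME assay on microsomes from liver (Homo sapiens) for metabolic stability, with a stated time of 10 min, tested at 0.5 uM; a higher number here means that more of the compound is left, a lower number that less of the compound is left. Compound 1 `CC(C)COc1ncc(-c2cn(C)c3cc(C(=O)NS(C)(=O)=O)ccc23)cc1Cl` gives 95%, compound 2 `CC(C)COc1ncc(-c2cn(C)c3cc(C(=O)NS(=O)(=O)C4CC4)c(F)cc23)cc1Cl` gives 100%, and compound 3 `Cn1cc(-c2ccc(C(F)(F)F)cc2)c2ccc(C(=O)NS(=O)(=O)C3CC3)cc21` gives 87%. Among these three numbers compound 3 stands lowest: its gap to compound 1 lies within the usual scatter, while its gap to compound 2 lies beyond it. Compound 4 `Cn1cc(-c2ccc(C(F)(F)F)cc2)c2ccc(C(=O)NS(C)(=O)=O)cc21` differs from compound 3 in one place: methyl in place of cyclopropyl on a sulfonyl sulfur. For the measured compounds named here, no measured pair isolates this exact change. Compound 1, which also carries a methylsulfonyl group, gives 95%, so no shift beyond the scatter is expected in this assay. The step of a number 1 percentage points higher from compound 3 to compound 4 (within the scatter) is expected to be small, in no clear direction. Compound 4 is expected to give about 88%, between 75% and 100%.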

Compound 4, percent of the compound remaining: 100%
For compound 4 the middle estimate is 12 percentage points below the measured one, within the range that was stated.
By their numbers in this assay, from the lowest: compounds 3, 1, 2 and 4 (each within the scatter of the next, the first and the last beyond it).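

In this assay, for the compounds shown here, the change from cyclopropyl to methyl on a sulfonyl sulfur gives a number 13 percentage points higher from compound 3 to compound 4 (beyond the scatter) and is the first measured pair to isolate this swap. It shows that this position can move the read-out beyond the scatter, at least with the core of compound 3. No measurement shown here explains the step. Going by these compounds, whether the swap acts the same way on the core of compound 1 remains open. So does what an ethyl group or a dimethylamino group on the same sulfur would give.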